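Lengthening the Branched Ester Chain of Compound 2

The source may report more compounds than this note shows. Statements on the series, on what has been measured and on what is new or still open speak of the compounds shown alone.

Measured so far:
compound 1, `CC(CC(=O)O[C@H]1C[C@@H](C)C=C2C=C[C@H](C)[C@H](CC[C@@H]3C[C@@H](O)CC(=O)O3)C21)C(F)(F)F`, gives 3.5 nM in an assay for inhibition of 3-hydroxy-3-methylglutaryl-coenzyme A reductase (Rattus norvegicus); on this read-out lower numbers stand for stronger inhibition and higher numbers for weaker inhibition
compound 2, `CCC(C)(CC)C(=O)O[C@H]1C[C@@H](C)C=C2C=C[C@H](C)[C@H](CC[C@@H]3C[C@@H](O)CC(=O)O3)C21`, gives 1.4 nM in this assay

Both compounds share one core and differ only in the acid that forms the ester. Going by the values given here, compound 2 has the lowest number of the two measured, and the single step known, a 2.5-fold lower number from compound 1 to compound 2 (0.40 log units; beyond the scatter), replaced a 2-(trifluoromethyl)propyl group by a 1-ethyl-1-methylpropyl group on the carbonyl carbon.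

Compound 3, `CCCC(CC)(CC)C(=O)O[C@H]1C[C@@H](C)C=C2C=C[C@H](C)[C@H](CC[C@@H]3C[C@@H](O)CC(=O)O3)C21`, has not yet been measured. It differs from compound 2 by ethyl in place of hydrogen on a saturated chain carbon, two bonds along the chain from a carbonyl carbon; read one bond further out, methyl becomes propyl, so 1-ethyl-1-methylpropyl becomes 1,1-diethylbutyl. Among the compounds with values here, no measured step describes adding an ethyl to this branch; the only step available, a 2.5-fold lower number from compound 1 to compound 2 (0.40 log units; beyond the scatter), swaps one branched group for another and bears only loosely on it. Since compound 2 already gives 1.4 nM with a saturated branched group on the carbonyl, the further ethyl is expected to leave the number close to that, within the scatter or barely beyond. Compound 3 is therefore estimated at 1.6 nM, between 0.6 nM and 4.5 nM. The expected step is a 1.1-fold higher number from compound 2 to compound 3 (0.06 log units; within the scatter).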

Compound 3, half-maximal inhibitory concentration: 1.9 nM
Compound 3: the middle estimate sits 1.2-fold (0.07 log units) below what was measured, and the stated range covers the measured number.
By their numbers in this assay, from the lowest: compounds 2, 3 and 1 (each within the scatter of the next, the first and the last beyond it).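

In this assay, ethyl in place of hydrogen on a saturated chain carbon, two bonds along the chain from a carbonyl carbon, gives a 1.4-fold higher number from compound 2 to compound 3 (0.13 log units; within the scatter), so turning 1-ethyl-1-methylpropyl into 1,1-diethylbutyl adds two carbons without a difference that stands clear of ordinary repeat variation. Measured against the trifluoromethyl-bearing ester, the result is a 1.8-fold lower number from compound 1 to compound 3 (0.27 log units; within the scatter), which means compound 3 cannot be told apart from compound 1 on this read-out, even though compound 2 can, so the three esters cannot be placed in a clean order. No supporting information is available to explain how this ester group relates to the number.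

The compounds shown leave open how much further this branch can grow, for instance whether a hexyl group in place of the propyl would still keep the number in the same range. They also leave open whether the branch accepts something other than plain carbon chains, such as an amine or a carboxylic acid in place of the propyl.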